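Dimethylamino swap on a series stuck at the limit

This account rests on a few compounds, and the source may have more. Where it says the series, first, only, none or still open, it means among the compounds named here.

In a functional assay on TOV21G cells (Homo sapiens) for antiproliferative activity, read by sulforhodamine B assay, with a stated time of 3 days (a lower number here means a stronger inhibitor of growth, a higher number a weaker inhibitor of growth), the measured compounds read as follows
Compound 1 `O=c1[nH]c2ccc(-c3csc(-c4ccc(F)c(F)c4)n3)cc2o1` gives > 50000 nM as a limit
Compound 2 `CCc1cc(F)ccc1-c1nc(-c2ccc3[nH]c(=O)oc3c2)cs1` gives > 50000 nM as a limit
Compound 3 `Cc1cc(F)ccc1-c1nc(-c2ccc3[nH]c(=O)n(CCN(C)C)c3c2)cs1` gives > 50000 nM as a limit

Going by the values given here, the series so far shows only the limit of > 50000 nM in this assay, at which 3 of the 3 values shown sit, and no graded number. Compound 2 therefore stands at the limit of this assay with > 50000 nM and no true value is known for it. Compound 4 `CN(C)Cc1cc(F)ccc1-c1nc(-c2ccc3[nH]c(=O)oc3c2)cs1` differs from compound 2 by one change dimethylamino in place of methyl on a saturated chain carbon bound to an aromatic carbon with dimethylamino in place of methyl on a saturated chain carbon bound to an aromatic carbon. Among the compounds with values here, no measured pair isolates this change. Compound 3 also carries a dimethylamino group, and it gives > 50000 nM as a limit. On that reading, no change beyond the usual scatter is expected in this assay and any shift would most likely be towards slightly stronger growth inhibition. The expected step is an at least 1.2-fold lower number from compound 2 to compound 4 (0.09 log units; that floor lies within the scatter) and no larger. The estimated value for compound 4 is 40000 nM within an expected range of 15000 nM to 50000 nM and a report of the limit alone remains the likeliest outcome.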

Compound 4, concentration for 50% growth inhibition: > 50000 nM
Compound 4 ended at the assay's limit; the forecaster's own chance of this, stated with the estimate: 75%; at least 1.2-fold (0.09 log units) between middle value and limit.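

Compound 2 and compound 4 both give only a limit in this assay, so no step can be read between them. The compounds shown leave open the true value of each compound and whether dimethylamino in place of methyl shifts growth inhibition at all: the limit of > 50000 nM in this assay, at which 4 of the 4 values shown sit.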